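Hydroxy to Chloro: Estimating Compound 4

The compounds below may be only part of what the source reports. "The series", "measured", "known", "first", "only" and "open" are said of these compounds alone.

compound 1 `O=C(/C=C/c1ccccc1)Nc1nc2ccccc2s1`: 646 umol/kg
compound 2 `CC(=O)N1N=C(Nc2nc3ccc(Cl)cc3s2)CC1c1ccc(O)cc1`: 106 umol/kg
compound 3 `CC(=O)N1N=C(Nc2nc3ccc([N+](=O)[O-])cc3s2)CC1c1ccc(O)cc1`: 162 umol/kg

These three numbers come from a functional assay on the whole organism (Hindlimb, strain albino) with Mus musculus as the target, in the maximal electroshock model, with a stated time of 0.5 h; on this read-out lower numbers stand for an effect already at smaller amounts and higher numbers for an effect only at larger amounts of compound. Compound 2 has the lowest of them, though its gap to compound 3 lies within the scatter, while its gap to compound 1 lies beyond it. Compound 4 `CC(=O)N1N=C(Nc2nc3ccc(Cl)cc3s2)CC1c1ccc(Cl)cc1` differs from compound 2 by chloro in place of hydroxy on an aromatic carbon. Among the compounds with values here, the only measured step, a 1.5-fold higher number from compound 2 to compound 3 (0.18 log units; within the scatter), sits on the shared core, not on the 4-hydroxyphenyl group, so it bears on this change only loosely; no measured pair touches the hydroxy group at all. With no direct guide, no step beyond the scatter is expected. The estimate for compound 4 is 120 umol/kg, with a range of 50 umol/kg to 300 umol/kg. That estimate means an expected step of a 1.1-fold higher number from compound 2 to compound 4 (0.05 log units; within the scatter).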

Compound 4, dose for half-maximal effect: 79.5 umol/kg
The estimate for compound 4 lay 1.5-fold (0.18 log units) above the measured number, and the stated range covers the measured number.
By their numbers in this assay, from the lowest: compounds 4, 2 and 3 (each within the scatter of the next, the first and the last beyond it); then compound 1.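

In this assay, within the data shown here, the change from 4-hydroxyphenyl to 4-chlorophenyl comes with a 1.3-fold lower number from compound 2 to compound 4 (0.12 log units; within the scatter), the first measured step at this position. Losing the hydroxy group, with its hydrogen-bond donor and acceptor, therefore moves the number no further than the scatter in this single pair. Nothing available explains this result. The compounds shown leave open how an amine or a carboxylic acid would read at this place. They also leave open whether the same change would read alike with nitro instead of chloro on the shared core.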